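Cyclopropane amides: from a chlorophenyl to a methylbenzyl amide

The source may hold more compounds than are shown below. What is called first, only, known or untested is meant among the compounds shown, and "the series" means these compounds.

This account concerns three cyclopropane carboxamides that share a trimethoxyphenyl-bearing core. Compound 1 `COc1cc([C@H]2C[C@]2(CO)C(=O)Nc2ccccc2Cl)cc(OC)c1OC` is measured in a functional assay on SW480 cells (Homo sapiens) for cytotoxicity, read by MTT assay, with a stated time of 48 h (a higher number here means a weaker inhibitor, a lower number a stronger inhibitor), where compound 1 gives 40200 nM. Its mirror image, compound 3 `COc1cc([C@@H]2C[C@@]2(CO)C(=O)Nc2ccccc2Cl)cc(OC)c1OC`, gives 10700 nM in this assay, a step of a 3.8-fold lower number from compound 1 to compound 3 (0.57 log units; beyond the scatter), which rests only on the fact that (the fact that compounds 1 and 3 differ only in the configuration as drawn). Compound 2 `COc1cc([C@H]2C[C@@]2(CO)C(=O)NCc2ccc(C)cc2)cc(OC)c1OC`, which carries the 4-methylbenzyl amide in another configuration, reaches only a limit in this assay: compound 2 gives > 100000 nM. Among the numbers shown, compound 3 stands lowest, with compound 1 as its nearest neighbour.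

The step now followed leads from compound 3 to compound 4 `COc1cc([C@@H]2C[C@@]2(CO)C(=O)NCc2ccc(C)cc2)cc(OC)c1OC`. The change is 4-methylbenzyl in place of 2-chlorophenyl on an amide-type nitrogen. For the measured compounds named here, no measured step bears directly on this exchange; the only guide is that the one compound carrying the 4-methylbenzyl group, compound 2, sits at the limit (the limit of > 100000 nM in this assay, at which 1 of the 3 values shown sits), while both 2-chlorophenyl compounds give numbers. The writer therefore expects the exchange to raise the number in this assay, with a real chance that only a limit is reported. Compound 4 is expected to give about 50000 nM in this assay, most likely between 15000 nM and 150000 nM. This estimate corresponds to an expected step of a 4.7-fold higher number from compound 3 to compound 4 (0.67 log units; beyond the scatter).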

Compound 4, half-maximal inhibitory concentration: 76300 nM
Beside the measured number, compound 4's estimate is 1.5-fold (0.18 log units) below it; the range from low to high includes it.
By their numbers in this assay, from the lowest: compound 3; then compounds 1 and 4 (each within the scatter of the next). At a limit, above all of these: compound 2.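

In this assay the exchange at the amide-type nitrogen now has a measured size: with the configuration of compound 3 kept, 4-methylbenzyl in place of 2-chlorophenyl gives a clear loss (a 7.1-fold higher number from compound 3 to compound 4 (0.85 log units; beyond the scatter)). The 4-methylbenzyl group is thus not tied to the limit seen earlier, since here it gives a number. Compound 2 remains at a limit of the assay (> 100000 nM), so the change at one saturated ring carbon that relates this pair can be stated only as a floor that does not clear the usual scatter (an at least 1.3-fold lower number from compound 2 to compound 4 (0.11 log units; that floor lies within the scatter)), and no effect of configuration on the 4-methylbenzyl amides can be claimed.

The exchange alters the ring substituent and the link to the nitrogen in a single step, so the compounds shown leave open which of the two carries the loss; a 2-chlorobenzyl group or a 4-methylphenyl group on the same nitrogen would separate them. Also open, as far as these compounds go, is whether the preference for one mirror image among the 2-chlorophenyl amides holds for other amides, such as a plain benzyl amide, once both mirror images give numbers.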